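Swapping 3-(trifluoromethyl)phenyl for 2-(trifluoromethyl)phenyl on a sulfonyl sulfur

The compounds below may be only part of what the source reports. "The series", "measured", "known", "first", "only" and "open" are said of these compounds alone.

In a functional assay on LNCaP cells (Homo sapiens) for antiproliferative activity, read by propidium iodide staining, with a stated time of 96 h (on this read-out lower numbers stand for stronger inhibition and higher numbers for weaker inhibition), compound 1 (`CC(O)(CS(=O)(=O)c1cccc(S(F)(F)(F)(F)F)c1)C(=O)Nc1cccc(S(F)(F)(F)(F)F)c1`) gives 11700 nM and compound 2 (`CC(O)(CS(=O)(=O)c1ccc(F)cc1)C(=O)Nc1cccc(S(F)(F)(F)(F)F)c1`) gives 32600 nM while compound 3 (`CC(O)(CS(=O)(=O)c1cccc(C(F)(F)F)c1)C(=O)Nc1cccc(S(F)(F)(F)(F)F)c1`) gives 21800 nM on the same read-out. Compound 3 therefore stands within the scatter of each of the other two, and no order can be drawn between it and either one.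

Compound 4 (`CC(O)(CS(=O)(=O)c1ccccc1C(F)(F)F)C(=O)Nc1cccc(S(F)(F)(F)(F)F)c1`) has the same atoms as compound 3, joined differently: it carries 2-(trifluoromethyl)phenyl in place of 3-(trifluoromethyl)phenyl on a sulfonyl sulfur.

Going by the values given here, two measured steps bear on this change (first a 1.5-fold lower number from compound 2 to compound 3 (0.17 log units; within the scatter) for an exchange of the group on the sulfonyl sulfur, then a 1.9-fold higher number from compound 1 to compound 3 (0.27 log units; within the scatter) for an exchange of the group on that same aromatic ring). Neither step leaves the scatter, so the expectation for compound 4 rests on these small sizes. Among the compounds with values here, no measured compound carries 2-(trifluoromethyl)phenyl, and the data therefore give no direction.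

In this assay the estimated outcome is a 1.1-fold higher number from compound 3 to compound 4 (0.04 log units; within the scatter) and no step beyond the scatter is expected in either direction. The estimate for compound 4 is an expected 24000 nM (estimated range 10000 nM to 55000 nM).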

Compound 4, half-maximal inhibitory concentration: 24900 nM
The estimate for compound 4 lay 1.0-fold (0.02 log units) below the measured number; measured number inside the range.
By their numbers in this assay, from the lowest: compounds 1, 3, 4 and 2 (each within the scatter of the next, the first and the last beyond it).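

In this assay, going by these compounds alone, the exchange of 3-(trifluoromethyl)phenyl for 2-(trifluoromethyl)phenyl on a sulfonyl sulfur gives a 1.1-fold higher number from compound 3 to compound 4 (0.06 log units; within the scatter) and is the first measured change that keeps the same group on the ring and alters only where it is attached, so this read-out does not separate these two isomers. The exchange of 4-fluorophenyl for 2-(trifluoromethyl)phenyl at the same place gives a 1.3-fold lower number from compound 2 to compound 4 (0.12 log units; within the scatter) and also stays within the scatter, so in these compounds neither of the two new comparisons shows a real difference between the groups on the sulfonyl sulfur. Nothing in the data shown accounts for these small steps, and no measurement bears on why the two isomers cannot be told apart.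

The compounds shown all keep an aromatic ring with fluorine-bearing groups on the sulfonyl sulfur, so it stays open whether a nitrile, an amine or a carboxylic acid on that ring would give a step beyond the scatter. As far as these compounds go, it also stays open whether a saturated chain in place of that ring would do so.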